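Branching of the amino side chain in the aorta series

The source may hold more compounds than are shown below. What is called first, only, known or untested is meant among the compounds shown, and "the series" means these compounds.

Compound 1 `CC(C)NC1=NS(=O)(=O)c2cc(Cl)ccc2N1` gives 36.3 uM in a functional assay (aorta) with Rattus norvegicus as the target; on this read-out lower numbers stand for an effect already at smaller amounts and higher numbers for an effect only at larger amounts of compound. Compound 2 `CC(C)(C)NC1=NS(=O)(=O)c2cc(Cl)ccc2N1` gives 1.4 uM in this assay; the step of a 26-fold lower number from compound 1 to compound 2 (1.41 log units; beyond the scatter) came with methyl in place of hydrogen on a saturated chain carbon bound to an amine nitrogen and two saturated chain carbons. Compound 3 `CCC(C)NC1=NS(=O)(=O)c2cc(Br)ccc2N1` gives 5.6 uM; how its core differs from the core of compound 1 is not broken down here. Compound 4 `CC(C)C(C)NC1=NS(=O)(=O)c2cc(Br)ccc2N1` is not yet measured and differs from compound 3 by methyl in place of hydrogen on a saturated chain carbon bound to two saturated chain carbons. This is the same kind of change as that between compound 1 and compound 2, but not the same: there the place was a saturated chain carbon bound to an amine nitrogen and two saturated chain carbons, here a saturated chain carbon bound to two saturated chain carbons. For compound 4 the expected step is a 2.2-fold lower number from compound 3 to compound 4 (0.35 log units; beyond the scatter), smaller than the measured step because a 26-fold lower number from compound 1 to compound 2 (1.41 log units; beyond the scatter) sat one bond nearer the amine nitrogen. Compound 4 is therefore estimated at 2.5 uM, with a range from 0.8 uM to 8 uM.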

Compound 4, concentration for half-maximal effect: 2.6 uM
Compound 4: middle estimate off by 1.0-fold (0.02 log units), on the low side; measured number inside the range.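

In this assay, methyl in place of hydrogen on a saturated chain carbon bound to two saturated chain carbons gave a 2.2-fold lower number from compound 3 to compound 4 (0.33 log units; beyond the scatter), so both steps run in the same direction, but the size did not carry over from one core to the other: the same change on two cores in this assay, a 26-fold lower number (1.41 log units; beyond the scatter) from compound 1 to compound 2 and a 2.2-fold lower number (0.33 log units; beyond the scatter) from compound 3 to compound 4, 12-fold (1.08 log units) apart, beyond the scatter of two such steps

This does not show that the core sets the size of the step, since the two steps differ in both the core and the place of the methyl on the chain. The compounds shown do not separate these two differences.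

Open, going by these compounds, is how each place behaves on the other core, and how a cyclopentyl group or a longer chain on the amine nitrogen compares.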